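This account rests on a few compounds, and the source may have more. Where it says the series, first, only, none or still open, it means among the compounds named here.

Measured so far:
compound 1, `N#C[C@@H]1CCCN1C(=O)[C@@H]1C[C@H](C(=O)N2CCOCC2)CN1`, 73% in an assay on the whole organism (plasma, strain Sprague-Dawley) for inhibition of Dipeptidyl peptidase 4 (Rattus norvegicus), with a stated time of 6 h, at a dose of 1 mg/kg by the oral route; a higher number here means more inhibition at the dose given (going by the name of the read-out), a lower number less inhibition;
compound 2, `CCC[C@@H]1CN[C@H](C(=O)N2CCC[C@H]2C#N)C1`, 50% in this assay.

Compound 2 stands lowest of the two numbers, with compound 1 sitting a full step above it, beyond the usual scatter. Compound 3, `N#C[C@@H]1CCCN1C(=O)[C@@H]1C[C@H](CO)CN1`, has not yet been measured. It differs from compound 2 by one change: hydroxy in place of ethyl on a saturated chain carbon bound to a saturated ring carbon. Going by the values given here, no measured pair shows this change, so the direction rests on expectation alone. A modest rise is expected here, in the step of a number 10 percentage points higher from compound 2 to compound 3 (within the scatter) from compound 2 to compound 3. Compound 3 is therefore estimated at 60%, within a range of 35% to 80%.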

Compound 3, a percentage reported as inhibition, in the whole organism at one dose (the size of the read-out at that dose, not a potency): 64%
Compound 3: middle estimate off by 4 percentage points, on the low side, within the range that was stated.
By their numbers in this assay, from the lowest: compound 2; then compounds 3 and 1 (each within the scatter of the next).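

In this assay, going by these compounds alone, hydroxy in place of ethyl on a saturated chain carbon bound to a saturated ring carbon gives the first readable step at this position, a number 14 percentage points higher from compound 2 to compound 3 (beyond the scatter). The earlier compounds shown here offered no pair differing in one place. The data give no measured explanation for this rise. This single pair shows one direction for one change, and it leaves open how an amine, a carboxylic acid or a longer chain would read at this position.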